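Swapping 1-phenylethyl for methyl on an amide

The compounds below may be only part of what the source reports. "The series", "measured", "known", "first", "only" and "open" are said of these compounds alone.

- compound 1 `CNC(=O)/C(C)=C/c1ccc(NC(=O)Nc2ccc(Cl)c(C(F)(F)F)c2)cc1`: 44300 nM
- compound 2 `CC(NC(=O)CCc1ccc(NC(=O)Nc2ccc(Cl)c(C(F)(F)F)c2)cc1)c1ccccc1`: > 50000 nM (a limit of the assay, not a number)

In a functional assay on HepG2 cells (Homo sapiens) for inhibition, read by MTT assay, with a stated time of 120 h (on this read-out lower numbers stand for stronger inhibition and higher numbers for weaker inhibition), compound 2 stands only at a limit, > 50000 nM, with no exact number. Compound 3 `CNC(=O)CCc1ccc(NC(=O)Nc2ccc(Cl)c(C(F)(F)F)c2)cc1` carries methyl in place of 1-phenylethyl on an amide-type nitrogen. Among the compounds with values here, no measured step guides this change, so only a modest gain in inhibition in this assay is expected, with compound 1 at 44300 nM as the sole exact reference. The expected size of the move is an at least 1.4-fold lower number from compound 2 to compound 3 (0.15 log units; that floor lies within the scatter), and it remains uncertain. Compound 3 is estimated at 35000 nM, within an expected range of 12000 nM to 70000 nM.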

Compound 3, half-maximal inhibitory concentration: 21000 nM
For compound 3 the middle estimate is 1.7-fold (0.22 log units) above the measured one; measured number inside the range.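

In this assay, methyl on the amide-type nitrogen gives stronger inhibition than 1-phenylethyl, with an at least 2.3-fold lower number from compound 2 to compound 3 (0.37 log units; beyond the scatter). Compound 2 has only a limit, not an exact number, so this step is a floor: the limit of > 50000 nM in this assay, at which 1 of the 3 values shown sits. The chain on the aromatic carbon also counts, since 2-(methylcarbamoyl)ethyl in place of 2-(methylcarbamoyl)prop-1-en-1-yl gives a 2.1-fold lower number from compound 1 to compound 3 (0.32 log units; beyond the scatter).

From the compounds shown here alone, whether ethyl or a longer chain on that nitrogen would keep the stronger inhibition remains open. So does the effect of an amine or a carboxylic acid in place of the methylcarbamoyl group.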